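Notes on the thiazolidinone urea series: a fluorine shift

A few compounds are considered here, and "the series" means these few. Any claim that something is new, unique, unknown or untested is made for them only; others in the source may bear on it.

Measured so far:
compound 1, `COc1cc2c(Oc3ccc(NC(=O)NN4C(=O)CSC4c4ccc(F)cc4)cc3)ccnc2cc1OC1CCN(C(=O)NC2CCCCC2)CC1`, 3420 nM
compound 2, `COc1cc2c(Oc3ccc(NC(=O)NN4C(=O)CSC4c4ccc(F)cc4)cc3)ccnc2cc1OC1CCN(C(=O)NCc2ccccc2)CC1`, 6600 nM
compound 3, `COc1cc2c(Oc3ccc(NC(=O)NN4C(=O)CSC4c4ccc(F)c(F)c4)cc3)ccnc2cc1OC1CCN(C(=O)NC(C)C)CC1`, 1060 nM

All three were measured in a functional assay on HT-29 cells (Homo sapiens) for inhibition, read by MTT assay; a lower number here means a stronger inhibitor, a higher number a weaker inhibitor. Compound 3 gives the lowest of the three numbers; the nearest is compound 1, the furthest compound 2, and both gaps lie beyond the scatter. Among the measured pairs, only compound 1 and compound 2 differ in one place: a 1.9-fold higher number from compound 1 to compound 2 (0.29 log units; within the scatter), a change on an amide-type nitrogen and therefore within the scatter.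

Compound 4, `COc1cc2c(Oc3ccc(NC(=O)NN4C(=O)CSC4c4ccccc4F)cc3)ccnc2cc1OC1CCN(C(=O)NC(C)C)CC1`, has not yet been measured in this assay. Relative to compound 3 the change is 2-fluorophenyl in place of 3,4-difluorophenyl on a saturated ring carbon. Going by the values given here, no measured step bears on this part of the molecule: the one single-point step, from compound 1 to compound 2, concerns the urea end, and compounds 1 and 2 differ from compound 3 at two places at once, so their values say nothing separable about the aryl fluorines. Among the compounds with values here, the only anchor is compound 3 at 1060 nM. On that basis no step beyond the scatter is expected in this assay, with the estimated step of a 1.4-fold higher number from compound 3 to compound 4 (0.15 log units; within the scatter) left open in direction. The expected value for compound 4 is therefore 1500 nM, with a range from 450 nM to 5000 nM.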

Compound 4, half-maximal inhibitory concentration: 410 nM
Compound 4: middle estimate off by 3.7-fold (0.56 log units), on the high side, outside the stated range (below it).
By their numbers in this assay, from the lowest: compound 4; then compound 3; then compounds 1 and 2 (each within the scatter of the next).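

In this assay, the aryl group on the saturated ring carbon of the five-membered ring proves able to move the number: a 2.6-fold lower number from compound 3 to compound 4 (0.41 log units; beyond the scatter), a modest step and the first measured at this position. The earlier single-place step concerned the urea end and stayed within the scatter, so this is the first change shown in the series to clear the scatter, and it does so with the urea end held constant and one fluorine fewer on the phenyl ring. The material at hand offers no measurement that accounts for the lower number.

2-Fluorophenyl replaces 3,4-difluorophenyl in a single step. The number of fluorines and their placement change together, and the pair cannot say which of the two matters, nor how an unsubstituted phenyl, a chlorophenyl or a pyridyl group would behave at this position. From the compounds shown here alone, it is also open whether the step carries over to the cyclohexyl and benzyl urea ends, or to a urea end bearing an amine or a carboxylic acid.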